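Notes on the step from compound 2 to compound 3

This account rests on a few compounds, and the source may have more. Where it says the series, first, only, none or still open, it means among the compounds named here.

Measured so far in an assay for inhibition of Polyunsaturated fatty acid 5-lipoxygenase (Homo sapiens), read by spectrophotometry, tested at 10 uM; a lower number here means less inhibition, a higher number more inhibition at the concentration tested (going by the name of the read-out):
compound 1, `CN(C(=S)NC(=O)c1ccccc1)c1ccccc1`: 78.7%
compound 2, `O=C(NC(=S)N(c1ccccc1)c1ccccc1)c1ccccc1`: 73.3%

Compound 2 holds the lowest of the two numbers, the gap to compound 1 being within the scatter. Compound 3 `COc1ccc(C(=O)NC(=S)N(c2ccccc2)c2ccccc2)cc1` differs from compound 2 by methoxy in place of hydrogen on an aromatic carbon. Among the compounds with values here, the single measured step, a number 5.4 percentage points lower from compound 1 to compound 2 (within the scatter), concerns another position and lies within the scatter, so no measured step bears directly on this change. Lacking any pointer either way, the number for compound 3 in this assay is expected close to that of compound 2, a step of a number 1.3 percentage points lower from compound 2 to compound 3 (within the scatter), not beyond the scatter. The estimate for compound 3 is 72%, between 55% and 88%.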

Compound 3, a percentage reported as inhibition, at one concentration (the size of the read-out at that concentration, not a potency): 19.2%
Beside the measured number, compound 3's estimate is 52.8 percentage points above it; the measured number lies below the stated range.
By their numbers in this assay, from the lowest: compound 3; then compounds 2 and 1 (each within the scatter of the next).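

In this assay, the change from phenyl to 4-methoxyphenyl gives a number 54.1 percentage points lower from compound 2 to compound 3 (beyond the scatter), so this aromatic carbon, para to a large group, is sensitive to substitution in a way that the earlier step on the amide-type nitrogen, a number 5.4 percentage points lower from compound 1 to compound 2 (within the scatter), did not reveal. Nothing available explains the drop.

Open, on these data alone, is whether the loss is specific to methoxy or also follows an amine, a carboxylic acid or a longer alkoxy chain at this carbon. Also open, as far as these compounds go, is whether methoxy has the same effect on the core of compound 1.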